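From propoxy to methoxy in the series

The source may report more compounds than this note shows. Statements on the series, on what has been measured and on what is new or still open speak of the compounds shown alone.

In a functional assay on MCF7 cells (Homo sapiens) for inhibition, read by sulforhodamine B assay, with a stated time of 48 h, tested at 50 uM (on this read-out lower numbers stand for less inhibition of growth and higher numbers for more inhibition of growth at the one concentration tested), compound 1 (`CCCOc1ccc([C@@H]2CC(=O)c3cc(CC=C(C)C)c(OC)cc3O2)cc1`) gives 60%. Compound 3 (`COc1ccc([C@@H]2C/C(=N/OCc3cn(-c4ccc(O)cc4)nn3)c3cc(CC=C(C)C)c(OC)cc3O2)cc1`) gives 63%, within the scatter of compound 1. Compound 2 (`COc1cc2c(cc1CCC(C)C)C(=O)C[C@@H](c1ccc(O)cc1)O2`) gives 81%, beyond the scatter above compound 1.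

Compound 4 (`COc1ccc([C@@H]2CC(=O)c3cc(CC=C(C)C)c(OC)cc3O2)cc1`) differs from compound 1 by hydrogen in place of ethyl on a saturated chain carbon bound to an oxygen on an aromatic ring, or propoxy to methoxy. Within the data shown here, no measured pair isolates this change, so the expectation is weakly grounded. The expected step of a number 7 percentage points higher from compound 1 to compound 4 (within the scatter) is small and upward, and it may not leave the scatter. Compound 4 is estimated at 67%, with an expected range of 50% to 84%.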

Compound 4, percent growth inhibition at one concentration: 65%
Estimate against measurement, compound 4: 2 percentage points above; the measured number falls inside the stated range.
By their numbers in this assay, from the lowest: compounds 1, 3 and 4 (each within the scatter of the next); then compound 2.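

Propoxy to methoxy is the first change in the series that can be read in isolation: in this assay, the step is a number 5 percentage points higher from compound 1 to compound 4 (within the scatter). At the one concentration tested, compound 1 and compound 4 cannot be told apart, so removing ethyl from this saturated chain carbon bound to an oxygen on an aromatic ring leaves the read-out unresolved. Nothing at hand gives a reason for this result. Still open, on these data alone, is whether a longer chain, such as butyl, or a chain ending in an amine would separate from compound 1 at this place.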